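The compounds below may be only part of what the source reports. "The series", "measured", "known", "first", "only" and "open" are said of these compounds alone.

Three compounds share one core and differ only in the ring on a saturated chain carbon bound to a sulfonamide nitrogen: compound 1 `NC(=O)[C@@H](CCC(F)(F)F)N(C[C@@H]1CCCCO1)S(=O)(=O)c1ccc(Cl)cc1`, compound 2 `NC(=O)[C@@H](CCC(F)(F)F)N(CC1CCOCC1)S(=O)(=O)c1ccc(Cl)cc1` and compound 3 `NC(=O)[C@@H](CCC(F)(F)F)N(C[C@H]1COCCO1)S(=O)(=O)c1ccc(Cl)cc1`. In an ADME assay on MDCKII-LE cells (Canis lupus familiaris) for permeability, read by transwell migration, in the apical to basolateral direction (a higher number here means that the compound crosses the layer faster, a lower number that the compound crosses the layer more slowly), compound 1 gives 15.4 10^-6 cm/s, compound 2 gives 26.3 10^-6 cm/s and compound 3 gives 20.6 10^-6 cm/s. Compound 3 cannot be told apart from the other two, since the data show a 1.3-fold higher number from compound 1 to compound 3 (0.13 log units; within the scatter) and a 1.3-fold lower number from compound 2 to compound 3 (0.11 log units; within the scatter). The remaining swap, from oxan-2-yl to oxan-4-yl, gives a 1.7-fold higher number from compound 1 to compound 2 (0.23 log units; within the scatter), so all three ring swaps stay inside the normal scatter of repeated measurements.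

Compound 4 `NC(=O)[C@@H](CCC(F)(F)F)N(C[C@@H]1CCCO1)S(=O)(=O)c1ccc(Cl)cc1` changes this ring again, with oxolan-2-yl in place of 1,4-dioxan-2-yl on a saturated chain carbon bound to a sulfonamide nitrogen. Within the data shown here, none of the measured compounds carries a five-membered ring, so there is no direct precedent for this swap. The closest guide is the set of three measured ring swaps, and the flat picture they give suggests another small step. In this assay, no change beyond the scatter is therefore expected, and the estimated step is a 1.0-fold lower number from compound 3 to compound 4 (0.01 log units; within the scatter). The estimated value for compound 4 is 20 10^-6 cm/s, with an expected range from 11 10^-6 cm/s to 36 10^-6 cm/s.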

Compound 4, apparent permeability: 22.4 10^-6 cm/s
For compound 4 the middle estimate is 1.1-fold (0.05 log units) below the measured one; the range from low to high includes it.
By their numbers in this assay, from the lowest: compounds 1, 3, 4 and 2 (each within the scatter of the next).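

Compound 4 brings the first five-membered ring to this series, and in this assay it cannot be told apart from any of the three six-membered rings (a 1.1-fold higher number from compound 3 to compound 4 (0.04 log units; within the scatter); a 1.2-fold lower number from compound 2 to compound 4 (0.07 log units; within the scatter); a 1.5-fold higher number from compound 1 to compound 4 (0.16 log units; within the scatter)). The step from compound 3 also takes away one ring atom, one oxygen and one hydrogen-bond acceptor, and even this larger change in the ring stays within the scatter, so on a saturated chain carbon bound to a sulfonamide nitrogen, all four uncharged oxygen-bearing rings shown read alike, with no compound going against that. Nothing here measures why these numbers stay so close, so the data offer no explanation for it.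

All four groups are saturated rings with at least one oxygen and no net charge, so the compounds shown leave open whether this flat picture would hold for an amine or a carboxylic acid at the same place. They also leave open what a longer chain between the ring and the sulfonamide nitrogen would do, and whether the opposite stereocentre in the oxolan-2-yl ring would read the same.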